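This account rests on a few compounds, and the source may have more. Where it says the series, first, only, none or still open, it means among the compounds named here.

Working notes on the series. In a functional assay on K562 cells (Homo sapiens) for cytotoxicity, read by fluorescence, with a stated time of 72 h (on this read-out lower numbers stand for stronger inhibition and higher numbers for weaker inhibition), compound 1 `CC(C)c1n[nH]c2c(NCc3ccc(-c4ccccn4)cc3)nc(NCCO)nc12` gives 38 nM, the second highest of three numbers. Compound 2 `CC(C)c1n[nH]c2c(NCc3ccc(-c4ccccn4)cc3)nc(N[C@@H]3CCCC[C@H]3N)nc12` gives 175 nM, and compound 3 `CC(C)c1n[nH]c2c(NCc3ccc(-c4ccccn4)cc3)nc(N3CCNCC3)nc12` gives 17 nM. Compound 4 `CC(C)c1n[nH]c2c(NCc3ccc(-c4ccccn4)cc3)nc(NCc3ccc(-c4ccccn4)cc3)nc12` differs from compound 1 as follows: 4-(pyridin-2-yl)phenyl in place of hydroxymethyl on a saturated chain carbon bound to a nitrogen on an aromatic ring. This puts 4-(pyridin-2-yl)phenyl in place of hydroxymethyl on a saturated chain carbon bound to a nitrogen on an aromatic ring. The closest measured change is a 4.6-fold higher number from compound 1 to compound 2 (0.66 log units; beyond the scatter), which also replaces the 2-hydroxyethyl group on that nitrogen. Against it stands a 2.2-fold lower number from compound 1 to compound 3 (0.35 log units; beyond the scatter), though that change also replaces the nitrogen substituent as a whole. Within the data shown here, no measured compound carries an aromatic ring here, so the direction is uncertain. A modest to large rise in this assay is expected, estimated as a 3.9-fold higher number from compound 1 to compound 4 (0.60 log units; beyond the scatter). For compound 4, the estimated value is 150 nM, with an expected range of 35 nM to 700 nM.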

Compound 4, half-maximal inhibitory concentration: 2540 nM
Estimate against measurement, compound 4: 17-fold (1.23 log units) below; the whole stated range lies below it.
By their numbers in this assay, from the lowest: compound 3; then compound 1; then compound 2; then compound 4.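

In this assay this saturated chain carbon does not accept every group: a 67-fold higher number from compound 1 to compound 4 (1.83 log units; beyond the scatter) follows when 4-(pyridin-2-yl)phenyl enters in place of hydroxymethyl. The earlier compounds shown here, all with non-aromatic groups here, stayed in a narrower band, and compound 4 now sets the top of the range. Nothing measured on hand accounts for this rise.

Open, from the compounds shown here alone, is whether a plain phenyl without the pyridin-2-yl already brings the same rise. Also open, going by these compounds, is whether a carboxylic acid or a longer hydroxyalkyl chain on that carbon keeps the number close to that of compound 1.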